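The compounds below may be only part of what the source reports. "The series", "measured", "known", "first", "only" and "open" are said of these compounds alone.

Compound 1 (`CCCCOC[C@H]1O[C@@H](CCC)[C@H](O)[C@@H](OCCCC)[C@@H]1OCCCC`) gives "not active" (no number reported)
Compound 2 (`C=CC[C@@H]1O[C@H](COCc2ccccc2)[C@@H](OCc2ccccc2)[C@H](OCc2ccccc2)[C@H]1O`) gives 15100 nM
Compound 3 (`O[C@@H]1[C@@H](OCc2ccccc2)[C@H](OCc2ccccc2)[C@@H](COCc2ccccc2)O[C@H]1CC1CC1`) gives "not active" (no number reported)

These results all come from a functional assay on HL-60 cells (Homo sapiens) for antiproliferative activity, read by MTT assay; a higher number here means a weaker inhibitor, a lower number a stronger inhibitor. Compound 3 has no number to its name: compound 3 gives "not active" (no number reported), and compound 1 is the only other entry of this kind, giving "not active" (no number reported). Within the data shown here, the only measured number belongs to compound 2, at 15100 nM, so compound 3 can be placed only by that missing number, not on a scale.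

The next compound, not yet measured, is compound 4 (`OCCC[C@@H]1O[C@H](COCc2ccccc2)[C@@H](OCc2ccccc2)[C@H](OCc2ccccc2)[C@H]1O`). The change is 2-hydroxyethyl in place of cyclopropyl on a saturated chain carbon bound to a saturated ring carbon, made on a saturated chain carbon bound to a saturated ring carbon. Cut one bond further out, the same difference reads cyclopropylmethyl to 3-hydroxypropyl.

Among the measured compounds shown here, no pair of measured compounds shows a step of this kind, so the data cannot size it. A small move towards stronger inhibition is expected, ending no better than the range of compound 2 at 15100 nM. A result with no number at all remains quite possible. For compound 4 the estimated value is 22000 nM, with an expected range from 9000 nM to 55000 nM.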

Compound 4, half-maximal inhibitory concentration: 19300 nM
The estimate for compound 4 lay 1.1-fold (0.06 log units) above the measured number; low and high end bracket the measured number.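

With compound 4, this position gets its first step that can be sized: in this assay, placing 2-hydroxyethyl where vinyl stood, on a saturated chain carbon bound to a saturated ring carbon, gives a 1.3-fold higher number from compound 2 to compound 4 (0.11 log units; within the scatter), so the two groups cannot be told apart in this assay. The chain can therefore end in a hydroxyl group and still give a measurable number, whereas compound 3, which carries cyclopropyl in the same place and differs from compound 4 only there, gives no number, so the size of that step cannot be read. No measurement shown here gives a reason for either result.

Three compounds with numbers or without them say little about how far this position can be pushed: an amine or a carboxylic acid at the end of the chain, or a chain longer than 3-hydroxypropyl, might or might not move the number beyond the usual scatter. Going by these compounds, the role of the benzyl groups also stays open, as compound 1 differs from the others in more than one place and so allows no clean comparison.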